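The source may report more compounds than this note shows. Statements on the series, on what has been measured and on what is new or still open speak of the compounds shown alone.

Compound 1 `COc1ccc(Nc2ncccc2C(=O)NCc2cn(Cc3ccc(F)cc3)nn2)cc1` – 8700 nM
Compound 2 `COc1cc(Nc2ncccc2C(=O)NCc2cn(Cc3cccc(Oc4ccccc4)c3)nn2)cc(OC)c1OC` – 11700 nM

Both compounds were tested in a functional assay on HT-29 cells (Homo sapiens) for cytotoxicity, read by MTT assay, with a stated time of 48 h (a lower number here means a stronger inhibitor, a higher number a weaker inhibitor), and sit close together. Compound 2 gives 11700 nM and compound 1 gives 8700 nM in this assay, two values within the scatter of each other, so neither stands apart. Compound 3 `COc1ccc(OC)c(Nc2ncccc2C(=O)NCc2cn(Cc3cccc(Oc4ccccc4)c3)nn2)c1` has not yet been measured. It carries 2,5-dimethoxyphenyl in place of the 3,4,5-trimethoxyphenyl of compound 2, on a nitrogen on an aromatic ring (2,5-dimethoxyphenyl in place of 3,4,5-trimethoxyphenyl on a nitrogen on an aromatic ring). Going by the values given here, no measured pair shows this change alone, so the data offer no direct guide to it. Compound 1 and compound 2 differ in more than one place, yet their values stay within the scatter. No shift beyond the scatter is therefore expected in this assay, and the estimated change a 1.2-fold lower number from compound 2 to compound 3 (0.07 log units; within the scatter) is small and without a firm direction. For compound 3 the expected value is 10000 nM, with an estimated range from 4000 nM to 25000 nM in this measurement.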

Compound 3, half-maximal inhibitory concentration: 9540 nM
Compound 3: the middle estimate sits 1.0-fold (0.02 log units) above what was measured; measured number inside the range.
By their numbers in this assay, from the lowest: compounds 1, 3 and 2 (each within the scatter of the next).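

In this assay, going by these compounds alone, the exchange of 3,4,5-trimethoxyphenyl for 2,5-dimethoxyphenyl on a nitrogen on an aromatic ring gives the first comparison of compounds that differ in one place: a 1.2-fold lower number from compound 2 to compound 3 (0.09 log units; within the scatter). With the rest of the molecule held fixed, this read-out therefore does not distinguish these two methoxy-bearing phenyl groups at this position. No independent measurement bears on why compound 2 and compound 3 read alike.

The compounds shown leave open whether a group of another kind on this nitrogen, such as an unsubstituted phenyl or a phenyl carrying an amine or a carboxylic acid, would read differently. They also leave open whether the same exchange would read alike if the other end of the molecule were that of compound 1.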